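Methyl in Place of Oxolanyl: Expected Permeability of Compound 3

The source may hold more compounds than are shown below. What is called first, only, known or untested is meant among the compounds shown, and "the series" means these compounds.

Measured compounds:
Compound 1, `Cc1cc(C)c(CN2CCc3c(Cl)cc([C@@H](CO)[C@@H]4CCCO4)c(Cl)c3C2=O)c(=O)[nH]1`: 4.3 10^-6 cm/s
Compound 2, `COc1cc(C)[nH]c(=O)c1CN1CCc2c(Cl)cc([C@H](O)C3COC3)c(Cl)c2C1=O`: 0.7 10^-6 cm/s

In an ADME assay on MDCK cells (Canis lupus familiaris) for permeability, read by LC-MS, with a stated time of 90 min, tested at 2 uM (on this read-out lower numbers stand for lower permeability and higher numbers for higher permeability), compound 1 gives 4.3 10^-6 cm/s, the higher of the two numbers measured, and compound 2 gives 0.7 10^-6 cm/s, a gap beyond the usual scatter. Compound 3, `Cc1cc(C)c(CN2CCc3c(Cl)cc([C@H](C)CO)c(Cl)c3C2=O)c(=O)[nH]1`, has not been measured. It differs from compound 1 by methyl in place of oxolan-2-yl on a saturated chain carbon bound to an aromatic carbon and a saturated chain carbon. Among the measured compounds shown here, with no step between measured compounds to lean on, a small step is expected, if any, in the direction of higher permeability, a 1.3-fold higher number from compound 1 to compound 3 (0.11 log units; within the scatter), possibly none beyond the scatter. Compound 3 is therefore estimated at 5.5 10^-6 cm/s, with a range from 2.5 10^-6 cm/s to 11 10^-6 cm/s.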

Compound 3, apparent permeability: 12.4 10^-6 cm/s
For compound 3 the middle estimate is 2.3-fold (0.35 log units) below the measured one, and the stated range ends below it.
By their numbers in this assay, from the lowest: compound 2; then compound 1; then compound 3.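

Among the compounds shown here, on the saturated chain carbon bound to an aromatic carbon and a saturated chain carbon, in this assay, methyl in place of oxolan-2-yl gives a 2.9-fold higher number from compound 1 to compound 3 (0.46 log units; beyond the scatter) and so provides the first readable step at this position. It shows that the oxolan-2-yl ring and its hydrogen-bond acceptor can be given up here without the number falling. Nothing available explains the rise.

This single step cannot separate the loss of the ring from the arrival of methyl. From the compounds shown here alone, how a longer chain, an open-chain ether or an amine on this carbon would read remains open.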